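The source may report more compounds than this note shows. Statements on the series, on what has been measured and on what is new or still open speak of the compounds shown alone.

Measured compounds:
Compound 1, `Cn1c(=O)c(S(=O)(=O)c2ccc(F)cc2)cc2cnc(Nc3cccc4[nH]ccc34)nc21`: 750 nM
Compound 2, `Cn1c(=O)c(S(=O)(=O)c2ccc(O)cc2)cc2cnc(Nc3ccc4[nH]ccc4c3)nc21`: 250 nM
Compound 3, `O=c1[nH]c2nc(Nc3ccc4[nH]ccc4c3)ncc2cc1S(=O)(=O)c1ccc(F)cc1F`: 15000 nM

In a functional assay on DU-145 cells (Homo sapiens) for inhibition, read by trypan blue exclusion, with a stated time of 72 h (a lower number here means a stronger inhibitor, a higher number a weaker inhibitor), compound 2 gives 250 nM, the lowest number of the three and thus the most potent inhibitor in this set. Compound 1 stands next, with a higher number that lies beyond the usual scatter, and compound 3 stands furthest away, with a much higher number. Since no single-point comparison between these three is available, only their values can be set side by side; no cause for their gaps is offered here.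

The untested compound 4, `Cn1c(=O)c(S(=O)(=O)c2ccc(F)cc2N)cc2cnc(Nc3ccc4[nH]ccc4c3)nc21`, shares the core of compound 2 and differs from it in one place: 2-amino-4-fluorophenyl in place of 4-hydroxyphenyl on a sulfonyl sulfur. The group that leaves carries one hydrogen-bond donor and one hydrogen-bond acceptor, and so does the group that enters, so the count of such features is unchanged, while a fluorine replaces an oxygen in the ring attached to the sulfonyl sulfur.

Because compound 1, which also carries a fluorine on that ring, gives 750 nM, a modest loss of potency is expected rather than a gain. The step from compound 2 to compound 4 is expected to be a 2.4-fold higher number from compound 2 to compound 4 (0.38 log units; beyond the scatter), small and toward a higher number. For compound 4 the expected value in this assay is 600 nM, within a range of 200 nM to 2000 nM.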

Compound 4, half-maximal inhibitory concentration: 3000 nM
The estimate for compound 4 lay 5.0-fold (0.70 log units) below the measured number; the whole stated range lies below it.
By their numbers in this assay, from the lowest: compound 2; then compound 1; then compound 4; then compound 3.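

Within the data shown here, this is the first comparison in the set in which only one place changes, so it isolates the group on the sulfonyl sulfur. In this assay, replacing 4-hydroxyphenyl with 2-amino-4-fluorophenyl gives a 12-fold higher number from compound 2 to compound 4 (1.08 log units; beyond the scatter), a large step beyond the usual scatter, so potency in these cells clearly depends on what this group is. The hydrogen-bond donor and acceptor counts are the same for both groups, so matching those counts does not preserve potency at this position, and nothing available explains why the number rises.

The step swaps several features at once: a hydroxyl group leaves while an amino group and a fluorine enter, and the compounds shown cannot say which of these changes accounts for the weaker inhibition. As far as these compounds go, it also remains open how other groups on the same ring, such as a methoxy group or a carboxylic acid, would read in this assay on the core shared by compound 2 and compound 4.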